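Chloro for Methoxy on a Thiophene-Bearing Core

This account rests on a few compounds, and the source may have more. Where it says the series, first, only, none or still open, it means among the compounds named here.

Compound 1 `COc1ccc(-c2nsc3c2NC(=O)CC3c2cccc(OC)c2)cc1`: 1390 nM in a functional assay on MDA-MB-231 cells (Homo sapiens) for antiproliferative activity, read by CellTiter-Glo, with a stated time of 96 h; a higher number here means a weaker inhibitor, a lower number a stronger inhibitor
Compound 2 `COc1ccc(-c2nsc3c2NC(=O)CC3c2cccc(Cl)c2)cc1`: 1620 nM
Compound 3 `COc1ccc(-c2nsc3c2NC(=O)CC3c2ccsc2)cc1`: 192 nM

Replacing the substituted phenyl on the saturated ring carbon with a thiophene lowers the number clearly: a 7.2-fold lower number from compound 1 to compound 3 (0.86 log units; beyond the scatter) and an 8.4-fold lower number from compound 2 to compound 3 (0.93 log units; beyond the scatter). The difference between the cores of compound 1 and compound 3 is thiophen-3-yl in place of 3-methoxyphenyl on a saturated ring carbon.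

Compound 4 `O=C1CC(c2ccsc2)c2snc(-c3ccc(Cl)cc3)c2N1` shares the core of compound 3 and is yet to be measured in this assay. It differs from compound 3 by chloro in place of methoxy on an aromatic carbon. The same kind of change separates compound 1 and compound 2, (chloro in place of methoxy on an aromatic carbon), though there the place is meta to a large group while in compound 4 it is para to a large group; that step was a 1.2-fold higher number from compound 1 to compound 2 (0.07 log units; within the scatter), within the scatter. Because a 1.2-fold higher number from compound 1 to compound 2 (0.07 log units; within the scatter) lies within the scatter, a similarly small step is expected: a 1.2-fold higher number from compound 3 to compound 4 (0.08 log units; within the scatter). Compound 4 is therefore estimated at 230 nM, most likely between 100 nM and 550 nM.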

Compound 4, half-maximal inhibitory concentration: 1630 nM
Compound 4: the middle estimate sits 7.1-fold (0.85 log units) below what was measured, outside the stated range (above it).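

In this assay, putting chloro in place of methoxy para to a large group gives an 8.5-fold higher number from compound 3 to compound 4 (0.93 log units; beyond the scatter) and costs much of the activity of compound 3. The same change therefore did not carry over with the same size from one core to the other: the same change on two cores in this assay, a 1.2-fold higher number (0.07 log units; within the scatter) from compound 1 to compound 2 and an 8.5-fold higher number (0.93 log units; beyond the scatter) from compound 3 to compound 4, 7.3-fold (0.86 log units) apart, beyond the scatter of two such steps. Within the data shown here, this rests on only two pairs, and the swap sits at a different place in each, so the data cannot separate the effect of the core from that of the place, nor explain the gap.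

Still open, going by these compounds, is how other groups at this place, such as fluoro, hydroxyl or an amine, would behave on the core of compound 3.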